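This account rests on a few compounds, and the source may have more. Where it says the series, first, only, none or still open, it means among the compounds named here.

In a functional assay on HCT-116 cells (Homo sapiens) for inhibition, read by CCK-8 assay, with a stated time of 48 h (on this read-out higher numbers stand for weaker inhibition and lower numbers for stronger inhibition), three compounds with a shared core differ only in the group on a thiocarbonyl carbon. Compound 1 `COc1ccc(CN(C(=O)CSC(=S)N2CCN(C(C)=O)CC2)c2cc(OC)c(OC)c(OC)c2)cc1` gives 1370 nM, and compound 2 `COc1ccc(CN(C(=O)CSC(=S)N2CCc3cc(OC)ccc32)c2cc(OC)c(OC)c(OC)c2)cc1` gives 9810 nM. Compound 3 `COc1ccc(CN(C(=O)CSC(=S)N2CCCc3cc(OC)ccc32)c2cc(OC)c(OC)c(OC)c2)cc1` has no exact number, only a limit of the assay, > 20000 nM.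

Compound 4 `COc1ccc(CN(C(=O)CSC(=S)N2CCc3ccccc3C2)c2cc(OC)c(OC)c(OC)c2)cc1` carries 1,2,3,4-tetrahydroisoquinolin-2-yl in place of the 6-methoxy-1,2,3,4-tetrahydroquinolin-1-yl of compound 3 (1,2,3,4-tetrahydroisoquinolin-2-yl in place of 6-methoxy-1,2,3,4-tetrahydroquinolin-1-yl on a thiocarbonyl carbon). This swap sits at the same place as all three measured steps. Leaving the 4-acetylpiperazin-1-yl group gave a 7.2-fold higher number from compound 1 to compound 2 (0.85 log units; beyond the scatter) and an at least 14-fold higher number from compound 1 to compound 3 (1.16 log units; beyond the scatter), so both replacements weakened inhibition. The step between the two methoxy-bearing groups, an at least 2.0-fold higher number from compound 2 to compound 3 (0.30 log units; that floor lies within the scatter), is only a floor and lies within the scatter.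

Among the measured compounds shown here, no measured step shows what happens when the methoxy group is absent, so this forecast is uncertain. Compound 2, at 9810 nM, is the closest exact guide among the replacements, which suggests that compound 4 will also inhibit weakly. The expected change is an at least 2.0-fold lower number from compound 3 to compound 4 (0.30 log units; that floor lies within the scatter), a small move towards stronger inhibition that may not clear the scatter. Compound 4 is estimated at 10000 nM, with an expected range of 3500 nM to 20000 nM.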

Compound 4, half-maximal inhibitory concentration: 15900 nM
Compound 4: middle estimate off by 1.6-fold (0.20 log units), on the low side; low and high end bracket the measured number.
By their numbers in this assay, from the lowest: compound 1; then compounds 2 and 4 (each within the scatter of the next). At a limit, above all of these: compound 3.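

Compound 4 shows that a group with no methoxy on it also falls well short of the 4-acetylpiperazin-1-yl group, with a 12-fold higher number from compound 1 to compound 4 (1.06 log units; beyond the scatter), so all three replacements shown on the thiocarbonyl carbon go the same way. In this assay, a 1.6-fold higher number from compound 2 to compound 4 (0.21 log units; within the scatter) does not separate compound 2 from compound 4, so these two different groups, only one of which carries a methoxy, cannot be told apart here. Compound 3 stands at a limit of the assay and not at an exact number, so an at least 1.2-fold lower number from compound 3 to compound 4 (0.09 log units; that floor lies within the scatter) is only a floor and cannot show how much the change from 6-methoxy-1,2,3,4-tetrahydroquinolin-1-yl to 1,2,3,4-tetrahydroisoquinolin-2-yl matters: the limit of > 20000 nM in this assay, at which 1 of the 4 values shown sits.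

The compounds shown leave open which part of the 4-acetylpiperazin-1-yl group goes with its stronger inhibition, since a piperazine with a free amine in place of the acetyl, or a morpholine ring, would be needed to divide that group into its parts. They also leave open whether a methoxy placed on the 1,2,3,4-tetrahydroisoquinolin-2-yl group would change the number at all.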